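This account rests on a few compounds, and the source may have more. Where it says the series, first, only, none or still open, it means among the compounds named here.

Measured compounds:
compound 1 `Cc1ccccc1C(=O)NC1CCN(c2ncnc3[nH]ncc23)CC1` — 6260 nM
compound 2 `Cc1cccc(C)c1NC(=O)NC1CCN(c2ncnc3[nH]ncc23)CC1` — 2160 nM
compound 3 `O=C(Nc1ccc(Br)cc1)NC1CCN(c2ncnc3[nH]ncc23)CC1` — 4030 nM

These three share a core and differ only in the aryl group attached to the carbonyl carbon or to the amide-type nitrogen. In an assay on isolated protein for inhibition of serine/threonine-protein kinase PAK 1 (Homo sapiens), read by ADP-Glo, with a stated time of 40 min (a higher number here means a weaker inhibitor, a lower number a stronger inhibitor), compound 3 gives 4030 nM, the second highest of the three numbers; its nearest neighbour is compound 1, its furthest compound 2, and both gaps lie within the scatter, so no order among the three can be claimed except a 2.9-fold lower number from compound 1 to compound 2 (0.46 log units; beyond the scatter), a modest step.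

Compound 4 `O=C(Nc1ccc(F)cc1F)NC1CCN(c2ncnc3[nH]ncc23)CC1` is the next step from compound 3: 2,4-difluorophenyl in place of 4-bromophenyl on an amide-type nitrogen. Within the data shown here, no measured step touches a difluorophenyl group. Among the measured compounds shown here, the only step that bears on it is a change of the aryl group on the same amide-type nitrogen, a 1.9-fold higher number from compound 2 to compound 3 (0.27 log units; within the scatter), which stayed within the scatter, and a 1.6-fold lower number from compound 1 to compound 3 (0.19 log units; within the scatter) likewise stayed within the scatter. On that basis no step beyond the scatter is expected in this assay for compound 4, in either direction; the estimate is a 1.2-fold lower number from compound 3 to compound 4 (0.06 log units; within the scatter).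

Compound 4 is therefore estimated at 3500 nM in this assay, with a range from 1400 nM to 9000 nM.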

Compound 4, half-maximal inhibitory concentration: 1140 nM
The estimate for compound 4 lay 3.1-fold (0.49 log units) above the measured number; measured number below the stated range.
By their numbers in this assay, from the lowest: compounds 4, 2, 3 and 1 (each within the scatter of the next, the first and the last beyond it).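

In this assay, among these compounds, a change of aryl group on the amide-type nitrogen now clears the scatter for the first time, with a 3.5-fold lower number from compound 3 to compound 4 (0.55 log units; beyond the scatter) in the swap of 4-bromophenyl for 2,4-difluorophenyl. The aryl group at this place can therefore move the number, although not every change does: with a 1.9-fold lower number from compound 2 to compound 4 (0.28 log units; within the scatter) there is no order between 2,4-difluorophenyl and 2,6-dimethylphenyl, and a 5.5-fold lower number from compound 1 to compound 4 (0.74 log units; beyond the scatter) is the largest step in the set, a change of the group on the carbonyl carbon. Nothing available explains why the 2,4-difluorophenyl change gives this step.

The compounds shown leave open whether a single fluorine on the phenyl ring would give the same number. They also leave open how the number responds to an amine or a carboxylic acid on that ring.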